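Replacing a tert-butyl ester with a cyclohexylmethyl ester

This account rests on a few compounds, and the source may have more. Where it says the series, first, only, none or still open, it means among the compounds named here.

Of the compounds shown here, three sharing one core have been tested in an assay on isolated protein for inhibition of Voltage-dependent L-type calcium channel subunit alpha-1C (Cavia porcellus); on this read-out lower numbers stand for stronger inhibition and higher numbers for weaker inhibition. Compound 1 `CC1=C(C(=O)OCC2CCCCC2)C(c2[nH]cnc2Cl)C(C(=O)OCC2CCCCC2)=C(C)N1` carries a cyclohexylmethyl group on each of its two ester oxygens; in this assay compound 1 gives 631 nM. Compound 2 `CCOC(=O)C1=C(C)NC(C)=C(C(=O)OC)C1c1[nH]cnc1Cl` has a methyl group on one ester oxygen and in this assay gives 661 nM. Compound 3 `CCOC(=O)C1=C(C)NC(C)=C(C(=O)OC(C)(C)C)C1c1[nH]cnc1Cl` carries a tert-butyl group on that same oxygen and in this assay gives 1660 nM, the highest of the three numbers, so it is the weakest inhibitor measured here. Among the compounds with values here, the only single-point step on record, a 2.5-fold higher number from compound 2 to compound 3 (0.40 log units; beyond the scatter), shows that enlarging methyl to tert-butyl at this ester oxygen weakened inhibition to a modest degree.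

Compound 4 `CCOC(=O)C1=C(C)NC(C)=C(C(=O)OCC2CCCCC2)C1c1[nH]cnc1Cl` is the next step from compound 3: cyclohexylmethyl in place of tert-butyl on an oxygen next to a carbonyl group. Within the data shown here, no measured pair covers exactly this exchange. What the numbers show is that compound 1, which already carries cyclohexylmethyl on both ester oxygens, has a value close to that of compound 2, while the tert-butyl group of compound 3 gave the higher number. Compound 4 is therefore expected to move back toward those lower numbers, with a step of a 2.6-fold lower number from compound 3 to compound 4 (0.41 log units; beyond the scatter) in this assay. The estimate for compound 4 in this assay is 650 nM, in a range from 280 nM to 1500 nM.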

Compound 4, half-maximal inhibitory concentration: 513 nM
The estimate for compound 4 lay 1.3-fold (0.10 log units) above the measured number; the measured number falls inside the stated range.
By their numbers in this assay, from the lowest: compounds 4, 1 and 2 (each within the scatter of the next); then compound 3.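

In this assay, the step of a 3.2-fold lower number from compound 3 to compound 4 (0.51 log units; beyond the scatter) shows that the higher number of compound 3 does not come with every large group on this ester oxygen: cyclohexylmethyl has more heavy atoms than tert-butyl, and its ring is new here, yet it restores a low number. The comparison with the small methyl group gives a 1.3-fold lower number from compound 2 to compound 4 (0.11 log units; within the scatter), so methyl and cyclohexylmethyl on this oxygen cannot be told apart in this read-out. On the other ester, a 1.2-fold lower number from compound 1 to compound 4 (0.09 log units; within the scatter) likewise leaves methyl in place of cyclohexyl on the saturated chain carbon without a difference beyond the scatter, and among these compounds only tert-butyl stands apart from the rest.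

Nothing available here explains why tert-butyl and cyclohexylmethyl differ. On these data alone, it remains open whether the low numbers would hold for a phenyl ring, a longer straight chain or a chain ending in an amine or a carboxylic acid on this oxygen.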